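The compounds below may be only part of what the source reports. "The series", "measured", "known", "first", "only" and "open" are said of these compounds alone.

Compound 1 `COc1ncnc2c1c(-c1ccccc1)cn2[C@@H]1O[C@H](CO)[C@@H](O)[C@H]1O`: > 20000 nM
Compound 2 `O=c1[nH]cnc2c1c(-c1cc3ccccc3o1)cn2[C@@H]1O[C@H](CO)[C@@H](O)[C@H]1O`: > 20000 nM
Compound 3 `COc1ncnc2c1c(-c1cc3ccccc3o1)cn2[C@@H]1O[C@H](CO)[C@@H](O)[C@H]1O`: > 20000 nM

In a functional assay on HepG2 cells (Homo sapiens) for antiproliferative activity, read by XTT assay, with a stated time of 72 h (on this read-out higher numbers stand for weaker inhibition and lower numbers for stronger inhibition), compound 1 gives > 20000 nM, which is a limit of the assay and not a number. Compound 2 likewise reaches only the limit > 20000 nM. Compound 3 also stops at the limit > 20000 nM. The change from compound 3 to compound 1 is phenyl in place of 1-benzofuran-2-yl on an aromatic carbon; its step that the two limits leave unreadable from compound 3 to compound 1 cannot be sized because the limit of > 20000 nM in this assay, at which 3 of the 3 values shown sit, holds both ends. Compound 4 `O=c1[nH]cnc2c1c(-c1ccccc1)cn2[C@@H]1O[C@H](CO)[C@@H](O)[C@H]1O` is not yet measured and differs from compound 2 by phenyl in place of 1-benzofuran-2-yl on an aromatic carbon, the same change at the same place. The difference between the core of compound 2 and that of compound 3 is not broken down here. The step from compound 2 to compound 4 in this assay is expected to be a step that the limit leaves unreadable from compound 2 to compound 4, resting only on the unreadable step that the two limits leave unreadable from compound 3 to compound 1. Compound 4 is therefore estimated at 30000 nM, expected between 15000 nM and 80000 nM.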

Compound 4, half-maximal inhibitory concentration: > 20000 nM
Compound 4 was reported as a limit; the forecaster's own chance of this, stated with the estimate: 85%; the middle value lies beyond the limit too.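

The step between compound 2 and compound 4 cannot be sized, because both compounds stop at a limit and not at a number: the limit of > 20000 nM in this assay, at which 4 of the 4 values shown sit.

The compounds shown leave open whether phenyl and 1-benzofuran-2-yl differ at all in antiproliferative activity.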